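The compounds below may be only part of what the source reports. "The series", "measured", "known", "first", "only" and "open" are said of these compounds alone.

Compound 1 `CC1CCN(C2CCN(S(=O)(=O)c3cccc(C(F)(F)F)c3)CC2)CC1`, compound 2 `CC1CCN(C2CCN(S(=O)(=O)c3ccc(Cl)c(C(F)(F)F)c3)CC2)CC1` and compound 3 `CC1CCN(C2CCN(S(=O)(=O)c3ccc(Cl)c(Cl)c3)CC2)CC1` share one core and were measured in an ADME assay on HCT-116 cells (Homo sapiens) for cytotoxicity, read by CellTiter-Glo, with a stated time of 72 h; a higher number here means a weaker inhibitor, a lower number a stronger inhibitor. Compound 1 gives > 5000 nM, which is a limit of the assay and not a number. Compound 2 gives > 5000 nM, which is also a limit. Compound 3 gives > 5000 nM, again a limit. Compound 2 therefore has no number of its own, and the whole set is summed up by the limit of > 5000 nM in this assay, at which 3 of the 3 values shown sit.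

Compound 4 `CC1CCN(C2CCN(S(=O)(=O)c3ccc([N+](=O)[O-])c(C(F)(F)F)c3)CC2)CC1` has not yet been measured. It differs from compound 2 by nitro in place of chloro on an aromatic carbon, ortho to a trifluoromethyl group.

Going by the values given here, two measured steps bear on this change, and neither has a readable size. Chloro in place of hydrogen gave a step that the two limits leave unreadable from compound 1 to compound 2, and chloro in place of trifluoromethyl gave a step that the two limits leave unreadable from compound 2 to compound 3. Among the compounds with values here, neither step brought a compound off the limit, so these two steps are the grounds for expecting little from the new group, although no measured step involves nitro itself.

The estimated step in this assay is a step that the limit leaves unreadable from compound 2 to compound 4, with no shift expected beyond the scatter in either direction. For compound 4 the estimated value is 7000 nM, with an expected range from 2500 nM to 20000 nM. A report as a limit alone is the likeliest outcome.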

Compound 4, half-maximal inhibitory concentration: > 5000 nM
Compound 4: a limit, no number; the forecaster's own chance of this, stated with the estimate: 80%; the middle value does not contradict the limit.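

In this assay compound 4 gives > 5000 nM, which is a limit of the assay and not a number. Going by these compounds alone, no step from compound 1 or compound 2 to compound 4 can be read. The compounds shown leave open how nitro, chloro and hydrogen compare at this place, and whether any change to the shared core would give a measurable value, the set standing at a single limit: the limit of > 5000 nM in this assay, at which 4 of the 4 values shown sit.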